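A 2-Chlorophenyl Swap at the Assay Limit

The source may report more compounds than this note shows. Statements on the series, on what has been measured and on what is new or still open speak of the compounds shown alone.

Going by the values given here, in a functional assay on SGC-7901 cells (Homo sapiens) for antiproliferative activity, read by MTT assay, with a stated time of 24 h (a higher number here means a weaker inhibitor, a lower number a stronger inhibitor), compound 1 (`O=C(NNc1cccc(Cl)c1)c1ccc(NS(=O)(=O)c2cnc(O)nc2O)cc1`) gives 11600 nM and is the only compound so far with a true number. Compound 2 (`Cc1ccccc1NNC(=O)c1ccccc1NS(=O)(=O)c1cnc(O)nc1O`) reads > 20000 nM and this is a limit of the assay, not a number. Compound 3 (`Cc1cccc(NNC(=O)c2ccccc2NS(=O)(=O)c2cnc(O)nc2O)c1`) reads > 20000 nM and this too is only a limit. Compound 3 therefore stands at the limit of > 20000 nM in this assay, at which 2 of the 3 values shown sit, and has no number of its own.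

Compound 4 (`O=C(NNc1ccccc1Cl)c1ccccc1NS(=O)(=O)c1cnc(O)nc1O`) differs from compound 3 in one place: 2-chlorophenyl in place of 3-methylphenyl on an amine nitrogen with 2-chlorophenyl in place of 3-methylphenyl on an amine nitrogen. Among the compounds with values here, the one measured step that bears on this change is a step that the two limits leave unreadable from compound 2 to compound 3 and it offers no size to carry forward. It therefore gives no direction either, so no shift beyond the scatter is expected in this assay for this swap. The estimated outcome is a number no higher from compound 3 to compound 4 (the limit leaves the size open) and it stays close to the limit. The result for compound 1 at 11600 nM shows that a reported number remains possible within this set. Compound 4 is estimated at 20000 nM with an expected range from 9000 nM to 45000 nM. A limit rather than a number may well be the expected outcome for compound 4.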

Compound 4, half-maximal inhibitory concentration: > 20000 nM
Compound 4: only a limit was reported (the forecaster's own chance of this, stated with the estimate: 60%); the middle value lies on the limit itself.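

Going by these compounds alone, compound 2, compound 3 and compound 4 all rest on a limit rather than a number in this assay, so no step among them can be read: the limit of > 20000 nM in this assay, at which 3 of the 4 values shown sit. The compounds shown leave open how far, and in which direction, a swap among 2-methylphenyl, 3-methylphenyl and 2-chlorophenyl on the amine nitrogen moves the activity.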